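Replacing the 2-(hydroxymethyl)phenyl group of compound 3

This account rests on a few compounds, and the source may have more. Where it says the series, first, only, none or still open, it means among the compounds named here.

Measured so far in a functional assay on HCT-116 cells (Homo sapiens) for inhibition, read by sulforhodamine B assay, with a stated time of 48 h, tested at 50 uM; on this read-out higher numbers stand for more inhibition of growth at the one concentration tested and lower numbers for less inhibition of growth 
- compound 1 `COc1ccc([C@@H]2C/C(=N/OCc3cn(-c4ccc(C#N)cc4)nn3)c3cc(CC=C(C)C)c(OC)cc3O2)cc1` gives 50% 
- compound 2 `COc1ccc([C@@H]2C/C(=N/OCc3cn(-c4cccc(CO)c4)nn3)c3cc(CC=C(C)C)c(OC)cc3O2)cc1` gives 27% 
- compound 3 `COc1ccc([C@@H]2C/C(=N/OCc3cn(-c4ccccc4CO)nn3)c3cc(CC=C(C)C)c(OC)cc3O2)cc1` gives 100% 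

Compound 3 stands highest of the three, and its gaps to the other two both lie beyond the scatter. Compound 4 `COc1ccc([C@@H]2C/C(=N/OCc3cn(-c4cc(OC)c(OC)c(OC)c4)nn3)c3cc(CC=C(C)C)c(OC)cc3O2)cc1` keeps the shared core and changes one group: 3,4,5-trimethoxyphenyl in place of 2-(hydroxymethyl)phenyl on an aromatic nitrogen of the five-membered aromatic ring with 3 nitrogen 3,4,5-trimethoxyphenyl in place of 2-(hydroxymethyl)phenyl on an aromatic nitrogen and its value is not yet known.

All three measured steps change a group at this same place. Arriving at 2-(hydroxymethyl)phenyl gave a number 73 percentage points higher from compound 2 to compound 3 (beyond the scatter) and also a number 50 percentage points higher from compound 1 to compound 3 (beyond the scatter) while the step between the two other groups was smaller, at a number 23 percentage points lower from compound 1 to compound 2 (beyond the scatter) for a modest change. Among the compounds with values here, no measured compound carries 3,4,5-trimethoxyphenyl, so the evidence is indirect: both compounds lacking 2-(hydroxymethyl)phenyl sit well below compound 3, and compound 4 lacks it too.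

In this assay the expected change is a number 55 percentage points lower from compound 3 to compound 4 (beyond the scatter) and this estimate means a large fall. The expected value for compound 4 is 45% with an estimated range from 15% to 85% as its wide span.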

Compound 4, percent growth inhibition at one concentration: 29%
For compound 4 the middle estimate is 16 percentage points above the measured one; the measured number falls inside the stated range.
By their numbers in this assay, from the lowest: compounds 2 and 4 (each within the scatter of the next); then compound 1; then compound 3.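

In this assay, the move to 3,4,5-trimethoxyphenyl gives a number 71 percentage points lower from compound 3 to compound 4 (beyond the scatter) and so adds a third group on the aromatic nitrogen that falls far short of 2-(hydroxymethyl)phenyl. The new compound also shows that carrying a hydroxymethyl group on this phenyl ring does not by itself set a compound apart, since the change gives a number 2 percentage points higher from compound 2 to compound 4 (within the scatter) even though compound 4 has no hydroxymethyl group and compound 2 does. Among the groups without that high number there is still some order, as the change gives a number 21 percentage points lower from compound 1 to compound 4 (beyond the scatter) and leaves 4-cyanophenyl above 3,4,5-trimethoxyphenyl, but nothing available explains these differences.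

The compounds shown leave open whether the high number of compound 3 depends on the hydroxyl of 2-(hydroxymethyl)phenyl or would also appear with another phenyl substituent in its place, such as an aminomethyl group or a carboxylic acid. With only one concentration tested, they also leave open whether the same order would hold at lower concentrations.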